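The source may hold more compounds than are shown below. What is called first, only, known or untested is meant among the compounds shown, and "the series" means these compounds.

In an ADME assay on Akata cells (Homo sapiens) for cytotoxicity, with a stated time of 7 days (on this read-out lower numbers stand for higher toxicity in this test and higher numbers for lower toxicity in this test), compound 3 `CCCCNc1nc(N)nc2c1ncn2/C=C1/CC1(CO)CO` has no number, only a limit of > 24000 nM. Compound 2 `Nc1nc(NC2CCCCC2)c2ncn(/C=C3/CC3(CO)CO)c2n1` also stands at a limit, > 24000 nM. Compound 1 `Nc1nc(OCC(F)(F)F)c2ncn(/C=C3/CC3(CO)CO)c2n1` is likewise a limit, > 20000 nM. Compound 3 therefore has no readable rank among these neighbours.

Compound 4 `Nc1nc(SCc2ccccc2)c2ncn(/C=C3/CC3(CO)CO)c2n1` keeps the shared core but carries benzylsulfanyl in place of butylamino on an aromatic carbon. The measured swaps at this same place are the closest guides: a step that the two limits leave unreadable from compound 1 to compound 2, a step that the two limits leave unreadable from compound 1 to compound 3 and a step that the two limits leave unreadable from compound 2 to compound 3. None of them gives a size that can be carried over, and none of them introduces benzylsulfanyl, so this guidance is thin. With every neighbour at a limit, no step beyond the scatter is expected, although a readable number just under those limits would not be surprising. The expected change is an at least 1.2-fold lower number from compound 3 to compound 4 (0.07 log units; that floor lies within the scatter). For compound 4 the estimated value is 20000 nM, with an expected range from 7000 nM to 30000 nM.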

Compound 4, half-maximal cytotoxic concentration: > 20000 nM
Compound 4 gave a limit, no number (the forecaster's own chance of this, stated with the estimate: 70%); the middle value sits exactly at the limit.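

Within the data shown here, compound 4, like compound 1, compound 2 and compound 3, stands only at a limit in this assay, and no step to compound 4 can be read. The compounds shown leave open what number each would give, and whether benzylsulfanyl, butylamino, cyclohexylamino and 2,2,2-trifluoroethoxy differ at all on this aromatic carbon.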